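This account rests on a few compounds, and the source may have more. Where it says the series, first, only, none or still open, it means among the compounds named here.

Of the compounds shown here, three sharing one core have been tested in a functional assay on CCRF-CEM cells (Homo sapiens) for antiproliferative activity, read by MTT assay, with a stated time of 48 h, tested at 50 uM; on this read-out higher numbers stand for a weaker effect at the one concentration tested and lower numbers for a stronger effect. Compound 1 `OCC(O)Cn1nc2c(Br)c(Br)c(Br)c(Br)c2n1` gives 27% in this assay. Going by the values given here, compound 2 `C[C@@H](O)CCn1nc2c(Br)c(Br)c(Br)c(Br)c2n1` gives 23% in this assay, and the single step between them, a number 4 percentage points lower from compound 1 to compound 2 (within the scatter), is within the scatter. Compound 3 `OC(CCn1nc2c(Br)c(Br)c(Br)c(Br)c2n1)c1cccc(Cl)c1` gives 0% in this assay; this is the lowest of the three numbers, and its gaps to compound 2 and to compound 1 are both beyond the scatter, so compound 3 stands as the strongest of the measured set.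

Compound 4 `OC(CCn1nc2c(Br)c(Br)c(Br)c(Br)c2n1)c1cccc(Br)c1` has not yet been measured. It differs from compound 3 by bromo in place of chloro on an aromatic carbon. No measured step touches this change: the one step shown, from compound 1 to compound 2, concerns the saturated chain and not the aromatic ring. Since a swap of one halogen for another on the ring is small and compound 3 already sits at the floor of the read-out, compound 4 is expected to give about 3%, with a range from 0% to 14%. The expected step is therefore a number 3 percentage points higher from compound 3 to compound 4 (within the scatter), essentially none beyond the scatter.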

Compound 4, a percentage reported as activity, at one concentration (the size of the read-out at that concentration, not a potency): 0%
Estimate against measurement, compound 4: 3 percentage points above; low and high end bracket the measured number.
By their numbers in this assay, from the lowest: compounds 3 and 4 (each within the scatter of the next); then compounds 2 and 1 (each within the scatter of the next).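

Going by these compounds alone, the swap on an aromatic carbon of the six-membered ring, meta to a large group, gives no change at the digits printed from compound 3 to compound 4 (within the scatter) in this assay, the first reading of any change at this position, since the earlier step concerned only the saturated chain. Either halogen is thus compatible with the result at the one concentration tested, with compound 3 at 0% and compound 4 at 0%, but a read-out that stands at zero for both cannot show whether the two differ in potency. Nothing available explains this outcome or links it to any property of either halogen.

The compounds shown leave open whether this position needs a halogen at all, or whether an unsubstituted phenyl, a methoxy group, an amine or a carboxylic acid there would give a similar number. They also leave open how compound 3 and compound 4 would compare at lower concentrations, where the read-out could separate them.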